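A few compounds are considered here, and "the series" means these few. Any claim that something is new, unique, unknown or untested is made for them only; others in the source may bear on it.

Compound 1 `COc1cc[nH]c1/C=C1\C(=O)Nc2ccc([N+](=O)[O-])c(N3CC[C@@H](N)C3)c21` gives < 10 nM in a functional assay on RKO cells (Homo sapiens) for antiproliferative activity, read by MTT assay, with a stated time of 5 days; a lower number here means a stronger inhibitor, a higher number a weaker inhibitor; this value is a limit of this assay.
Compound 2 `COc1cc[nH]c1/C=C1\C(=O)Nc2ccc([N+](=O)[O-])c(-n3ccnc3)c21` gives 3920 nM in this assay.
Compound 3 `COc1cc[nH]c1/C=C1\C(=O)Nc2ccc([N+](=O)[O-])c(N3CCC(N)CC3)c21` gives < 10 nM in this assay, again a limit.

Compound 3 thus stands at the limit of this assay, where its number is not read; compound 1 stands at the same limit (the limit of < 10 nM in this assay, at which 2 of the 3 values shown sit), so the step that the two limits leave unreadable from compound 1 to compound 3 stays unreadable. The two readable steps on this aromatic carbon are both large: an at least 390-fold higher number from compound 1 to compound 2 (2.59 log units; beyond the scatter) and an at least 390-fold lower number from compound 2 to compound 3 (2.59 log units; beyond the scatter). They show that exchanging the group at this position can move the number far in this assay, but neither of them copies the change now in question.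

Compound 4 `COc1cc[nH]c1/C=C1\C(=O)Nc2ccc([N+](=O)[O-])c(N[C@H]3CC[C@H](O)C3)c21` differs from compound 3 in one place: (3-hydroxycyclopentyl)amino in place of 4-aminopiperidin-1-yl on an aromatic carbon. The entering (3-hydroxycyclopentyl)amino group keeps an amino nitrogen on the aromatic carbon, unlike the 1H-imidazol-1-yl of compound 2, so a collapse of the size seen there is not expected, but since compound 3 sits at a limit, a rise of any size would be readable only upward. Compound 4 is expected to give 60 nM, within 8 nM to 600 nM, an estimated step of an at least 6.0-fold higher number from compound 3 to compound 4 (0.77 log units; beyond the scatter).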

Compound 4, half-maximal inhibitory concentration: 339 nM
Estimate against measurement, compound 4: 5.7-fold (0.75 log units) below; low and high end bracket the measured number.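

An amino nitrogen on the aromatic carbon is thus not enough to hold the number at the limit: (3-hydroxycyclopentyl)amino gives an at least 33-fold higher number from compound 3 to compound 4 (1.53 log units; beyond the scatter) and an at least 33-fold higher number from compound 1 to compound 4 (1.53 log units; beyond the scatter) in this assay at this position. Against 1H-imidazol-1-yl the same group still gains, with a 12-fold lower number from compound 2 to compound 4 (1.06 log units; beyond the scatter) as the step, so compound 4 gives a value lying between the earlier extremes. The first two steps are open-ended and the step from compound 1 to compound 3 cannot be read: the limit of < 10 nM in this assay, at which 2 of the 4 values shown sit.

Compound 4 changes the ring size, the ring atoms and the hydroxyl at once, so the compounds shown leave open which of these carries the rise. On these data alone, a (3-aminocyclopentyl)amino group, with a primary amine in place of the hydroxyl, would bear on this, and the other stereoisomers of the entering group also remain open.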